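The source may hold more compounds than are shown below. What is called first, only, known or untested is meant among the compounds shown, and "the series" means these compounds.

Working notes on the series. In a functional assay on KB cells (Homo sapiens) for inhibition (on this read-out higher numbers stand for weaker inhibition and lower numbers for stronger inhibition), compound 1 (`CC(=O)OC1C(CF)OC(n2c(Cl)nc3cc(Cl)c(Cl)cc32)C1OC(C)=O`) gives 100000 nM, compound 2 (`CC(=O)OC1C(CCl)OC(n2c(Cl)nc3cc(Cl)c(Cl)cc32)C1OC(C)=O`) gives 90000 nM and compound 3 (`CC(=O)OC1C(CN=[N+]=[N-])OC(n2c(Cl)nc3cc(Cl)c(Cl)cc32)C1OC(C)=O`) gives 70000 nM. Compound 3 cannot be separated from the other two: a 1.4-fold lower number from compound 1 to compound 3 (0.15 log units; within the scatter) and a 1.3-fold lower number from compound 2 to compound 3 (0.11 log units; within the scatter). Compound 4 (`CSCC1OC(n2c(Cl)nc3cc(Cl)c(Cl)cc32)C(OC(C)=O)C1OC(C)=O`) carries methylsulfanyl in place of azido on a saturated chain carbon bound to a saturated ring carbon. Those two steps and a 1.1-fold lower number from compound 1 to compound 2 (0.05 log units; within the scatter) bear on this change, as all are exchanges at that same place and all lie within the scatter. For the measured compounds named here, no methylsulfanyl compound has a measured value yet. The expected step in this assay is a 1.1-fold higher number from compound 3 to compound 4 (0.06 log units; within the scatter), with no change beyond the scatter. Compound 4 is estimated at 80000 nM, with an expected range of 40000 nM to 150000 nM.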

Compound 4, half-maximal inhibitory concentration: 70000 nM
Beside the measured number, compound 4's estimate is 1.1-fold (0.06 log units) above it, within the range that was stated.
By their numbers in this assay, from the lowest: compounds 3, 4, 2 and 1 (each within the scatter of the next).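

In this assay, methylsulfanyl behaves like the other groups on a saturated chain carbon bound to a saturated ring carbon, with every new step within the scatter (no change at the digits printed from compound 3 to compound 4 (within the scatter)) (a 1.3-fold lower number from compound 2 to compound 4 (0.11 log units; within the scatter)) (a 1.4-fold lower number from compound 1 to compound 4 (0.15 log units; within the scatter)). The exchanges at this place now extend to a sulfur-bearing group, and the four compounds still cannot be separated. No evidence on the reason for this is available. From the compounds shown here alone, whether an amine, a carboxylic acid or a longer chain at this place would give a step beyond the scatter remains open.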